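Sec-butyl to 2-(methylsulfanyl)ethyl: an expected small step

The source may report more compounds than this note shows. Statements on the series, on what has been measured and on what is new or still open speak of the compounds shown alone.

Compound 1, `O=C(CN(c1nc(Cl)nc2[nH]cnc12)C1CC1)NCC(=O)OCc1ccccc1`: 41.9% in a functional assay on the whole organism (Tail, strain ICR) with Mus musculus as the target, in the tail flick test, with a stated time of 60 min, at a dose of 25 umol/kg by the oral route; a higher number here means a stronger effect of the compound at the dose given, a lower number a weaker effect
Compound 2, `CC[C@H](C)[C@H](NC(=O)CN(c1nc(Cl)nc2[nH]cnc12)C1CC1)C(=O)OCc1ccccc1`: 40.6%

Compound 3 is `CSCC[C@H](NC(=O)CN(c1nc(Cl)nc2[nH]cnc12)C1CC1)C(=O)OCc1ccccc1` and has not yet been measured. Compound 2 cannot be told apart from compound 1 on the numbers shown, since the only measured step, a number 1.3 percentage points lower from compound 1 to compound 2 (within the scatter), sits within the scatter. Compound 3 differs from compound 2 by 2-(methylsulfanyl)ethyl in place of sec-butyl on a saturated chain carbon bound to an amide-type nitrogen and a carbonyl carbon. Among the measured compounds shown here, the one step that bears on this change is the step from hydrogen to sec-butyl at the same place, and it was small; no step exchanging one chain for another at this place has been measured. The expectation for compound 3 is therefore no step beyond the scatter, the estimated step being a number 0.6 percentage points lower from compound 2 to compound 3 (within the scatter) in this assay. Compound 3 is expected to give about 40%, with a range from 25% to 55%.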

Compound 3, a percentage reported as activity, at one dose (the size of the read-out at that dose, not a potency): 30.8%
Estimate against measurement, compound 3: 9.2 percentage points above; the range from low to high includes it.
By their numbers in this assay, from the lowest: compounds 3, 2 and 1 (each within the scatter of the next, the first and the last beyond it).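

Among the compounds shown here, at this place, on the saturated chain carbon bound to an amide-type nitrogen and a carbonyl carbon, a chain can now be told apart from hydrogen in this assay: putting 2-(methylsulfanyl)ethyl in place of hydrogen gives a number 11.1 percentage points lower from compound 1 to compound 3 (beyond the scatter) and is the first step here to clear the usual variation. Exchanging sec-butyl for 2-(methylsulfanyl)ethyl gives a number 9.8 percentage points lower from compound 2 to compound 3 (within the scatter), so these two chains cannot be separated from each other directly. No measurement at hand offers a cause for either step.

The compounds shown leave open whether the step from hydrogen goes with the sulfur atom or with the unbranched chain, which a plain butyl chain at this place could separate. Also open, on these data alone, is how a chain ending in an amine or a carboxylic acid would compare.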